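Benzofuran in place of methoxyphenyl on a shared core

This account rests on a few compounds, and the source may have more. Where it says the series, first, only, none or still open, it means among the compounds named here.

Measured compounds:
compound 1 `Cc1ccccc1-n1nc(C)c2c1NC(=O)[C@H](C)S[C@@H]2c1ccc(-c2ccoc2)cc1` — in an assay on isolated protein for agonist activity at Bile acid receptor (Homo sapiens), read by AlphaScreen, with a stated time of 30 min (a lower number here means that less compound is needed, a higher number that more compound is needed for the effect), compound 1 gives 3500 nM
compound 2 `CCCc1ccccc1-n1nc(C)c2c1NC(=O)[C@H](C)S[C@@H]2c1ccc(Oc2ccccc2)cc1` — in this assay compound 2 gives 1100 nM
compound 3 `COc1cccc(-c2ccc([C@H]3S[C@@H](C)C(=O)Nc4c3c(C)nn4-c3ccccc3C)cc2)c1` — in this assay compound 3 gives 1800 nM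

Of these three numbers, compound 3 sits second highest. Among the compounds with values here, its value and that of compound 2 lie within the usual scatter of each other, as do its value and that of compound 1; the change a 1.9-fold lower number from compound 1 to compound 3 (0.29 log units; within the scatter) is therefore no real step. All three share the same core and differ only in groups at its edges.

Compound 4 `Cc1ccccc1-n1nc(C)c2c1NC(=O)[C@H](C)S[C@@H]2c1ccc(-c2cc3ccccc3o2)cc1` is the next compound, differing from compound 3 by 1-benzofuran-2-yl in place of 3-methoxyphenyl on an aromatic carbon. Within the data shown here, the only measured step that bears on this position is the one from compound 1 to compound 3, which swapped one aromatic ring for another at the same place and stayed within the scatter. Compound 4 is therefore expected to show no step beyond the scatter, a 1.2-fold lower number from compound 3 to compound 4 (0.08 log units; within the scatter). The estimate for compound 4 is 1500 nM, with a range from 400 nM to 5000 nM.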

Compound 4, half-maximal effective concentration: 1500 nM
Beside the measured number, compound 4's estimate shows no gap at the digits printed, within the range that was stated.
By their numbers in this assay, from the lowest: compounds 2, 4, 3 and 1 (each within the scatter of the next, the first and the last beyond it).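

At this position, para to a large group, this assay now gives its first step beyond the scatter, a 2.3-fold lower number from compound 1 to compound 4 (0.37 log units; beyond the scatter), so the group placed here can change the number, though only modestly. The other new step, a 1.2-fold lower number from compound 3 to compound 4 (0.08 log units; within the scatter), stays within the scatter, so 1-benzofuran-2-yl and 3-methoxyphenyl cannot be told apart here, even though only the first of them differs clearly from furan-3-yl. Nothing available explains why 1-benzofuran-2-yl and furan-3-yl differ in this way.

All three groups compared at this position are aromatic and contain only carbon and oxygen. From the compounds shown here alone, it remains open how the number would respond to an amine, a carboxylic acid or a plain alkyl chain in the same place.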